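Removing the methoxy from the aryl group of compound 1

The source may hold more compounds than are shown below. What is called first, only, known or untested is meant among the compounds shown, and "the series" means these compounds.

Compound 1 `COc1ccc(-c2[nH]c3ccccc3c2/C=C(\C#N)S(=O)(=O)c2ccccc2)cc1` gives 1900 nM in a functional assay on OVCAR-5 cells (Homo sapiens) for inhibition, read by sulforhodamine B assay, with a stated time of 48 h (on this read-out higher numbers stand for weaker inhibition of growth and lower numbers for stronger inhibition of growth), the lowest of the three numbers in hand. Among the compounds with values here, compound 3 `COc1ccc(-c2[nH]c3ccc(OC)cc3c2/C=C(\C#N)S(=O)(=O)c2ccccc2)cc1` gives 4600 nM and compound 2 `CCOC(=O)C(=Cc1c(-c2ccccc2)[nH]c2ccccc12)C(=O)OCC` gives 18500 nM; compound 2 carries a phenyl in place of the 4-methoxyphenyl but also differs elsewhere, so no single step connects it to compound 1 and its number only shows that such a phenyl analogue can sit well above compound 1.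

The unmeasured compound 4 `N#C/C(=C\c1c(-c2ccccc2)[nH]c2ccccc12)S(=O)(=O)c1ccccc1` differs from compound 1 in one place: hydrogen in place of methoxy on an aromatic carbon, read more widely as 4-methoxyphenyl to phenyl. Within the data shown here, the only measured step of the same kind is a 2.4-fold higher number from compound 1 to compound 3 (0.38 log units; beyond the scatter), but that methoxy sits on a different ring within the shared core, so it bears only loosely on the present change. The three compounds do not settle whether a methoxy on the six-membered aromatic ring of carbon only matters. A small step is expected, of open direction. Compound 4 is expected to give 2500 nM, with a range from 1000 nM to 6500 nM. That estimate means an expected step of a 1.3-fold higher number from compound 1 to compound 4 (0.12 log units; within the scatter).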

Compound 4, concentration for 50% growth inhibition: 13900 nM
Beside the measured number, compound 4's estimate is 5.6-fold (0.75 log units) below it, and the stated range ends below it.
By their numbers in this assay, from the lowest: compound 1; then compound 3; then compounds 4 and 2 (each within the scatter of the next).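

In this assay, within the data shown here, the methoxy on the six-membered aromatic ring of carbon only, para to a large group, clearly matters: its replacement by hydrogen gives a 7.3-fold higher number from compound 1 to compound 4 (0.86 log units; beyond the scatter), a step beyond the scatter rather than the small change the earlier compounds left possible. The number therefore rises both on losing this methoxy and on gaining the methoxy on the shared core, as in a 2.4-fold higher number from compound 1 to compound 3 (0.38 log units; beyond the scatter), so the two places cannot be read as one methoxy effect. No measurement in hand gives a cause for the step at this position.

As far as these compounds go, whether the methoxy itself is needed remains open, since a hydroxyl, a chlorine or an amine at this place would separate it from other groups. Also open, from the compounds shown here alone, is whether a longer chain, such as ethoxy, is accepted there.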